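Removing the fluoro from a potent quinolone amide

The source may hold more compounds than are shown below. What is called first, only, known or untested is meant among the compounds shown, and "the series" means these compounds.

Of the compounds shown here, two sharing one core have been measured in an assay on isolated protein for inhibition of tyrosine-protein kinase receptor UFO (Homo sapiens), read by FRET and Z'-LYTE, with a stated time of 1.5 h; on this read-out higher numbers stand for weaker inhibition and lower numbers for stronger inhibition. Compound 1 `Cc1c(C(=O)Nc2ccc(Oc3ncnc4[nH]cc(-c5ccccc5)c34)c(F)c2)c(=O)c2ccccc2n1C` carries a hydrogen where compound 2 `CCc1ccc2c(c1)c(=O)c(C(=O)Nc1ccc(Oc3ncnc4[nH]cc(-c5ccccc5)c34)c(F)c1)c(C)n2C` carries an ethyl on an aromatic carbon. Compound 1 reaches only a limit of the assay in this assay, giving > 10000 nM. In this assay compound 2 gives 6 nM, the only true number shown, so compound 2 stands as the single measured reference point. The step of an at least 1600-fold lower number from compound 1 to compound 2 (3.22 log units; beyond the scatter) is large, but it concerns the ethyl, not the fluoro.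

Compound 3 `CCc1ccc2c(c1)c(=O)c(C(=O)Nc1ccc(Oc3ncnc4[nH]cc(-c5ccccc5)c34)cc1)c(C)n2C` differs from compound 2 by hydrogen in place of fluoro on an aromatic carbon. Within the data shown here, no measured step touches this fluoro, so the only measured step gives no direct guide; its size cannot be carried over to a change at a different place. With nothing pointing to a large effect, the expectation is a step within or near the scatter. For compound 3 the estimated value in this assay is 12 nM, with a range from 4 nM to 40 nM. This estimate implies a step of a 2.0-fold higher number from compound 2 to compound 3 (0.30 log units; within the scatter), expected to be modest.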

Compound 3, half-maximal inhibitory concentration: 105 nM
Beside the measured number, compound 3's estimate is 8.8-fold (0.94 log units) below it, outside the stated range (above it).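

In this assay, hydrogen in place of fluoro gives an 18-fold higher number from compound 2 to compound 3 (1.24 log units; beyond the scatter) on a six-membered aromatic ring of carbon only, ortho to a large group and meta to a large group. Among these compounds, until now the only measured step concerned the ethyl, so this is the first measured sign that a second place in the molecule can also move the number well beyond the scatter. What leaves is just one heavy atom, a fluorine, with no ring, no hydrogen-bond donor or acceptor and no net charge, so even an exchange this small can have a large effect in this series.

Chloro, methyl or methoxy at the same place could keep the number close to that of compound 2 or lose as much as hydrogen does, and whether the fluoro matters as much without the ethyl also stays open. Nothing among the data shown bears on why this exchange has so large an effect.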